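Shortening the Amide Chain on a Shared Nucleoside Core

The compounds below may be only part of what the source reports. "The series", "measured", "known", "first", "only" and "open" are said of these compounds alone.

The shared core of compound 1 `NC(=O)[C@H]1OC(n2cnc3c(N)ncnc32)[C@H](O)[C@@H]1O` carries an amide with a bare nitrogen; in an assay on cell membranes for binding affinity to 2-oxoglutarate receptor 1 (Rattus norvegicus), read by radioligand binding (on this read-out lower numbers stand for stronger inhibition and higher numbers for weaker inhibition), compound 1 gives 64 nM. Compound 2 `CCCCCCNC(=O)[C@H]1OC(n2cnc3c(N)ncnc32)[C@H](O)[C@@H]1O` adds a hexyl group on that nitrogen, and in this assay compound 2 gives 19 nM. Compound 3 `CCCCCCCNC(=O)[C@H]1OC(n2cnc3c(N)ncnc32)[C@H](O)[C@@H]1O` carries a heptyl group there, and in this assay compound 3 gives 20 nM. Compound 3 stands second highest of these three numbers: close to compound 2, with a 1.1-fold higher number from compound 2 to compound 3 (0.02 log units; within the scatter), and separated from compound 1 by a 3.2-fold lower number from compound 1 to compound 3 (0.51 log units; beyond the scatter).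

Compound 4 `CCC(C)NC(=O)[C@H]1OC(n2cnc3c(N)ncnc32)[C@H](O)[C@@H]1O` differs from compound 3 by sec-butyl in place of heptyl on an amide-type nitrogen. Two kinds of measured step bear on this. Adding a chain to the bare nitrogen gave a 3.4-fold lower number from compound 1 to compound 2 (0.53 log units; beyond the scatter) and a 3.2-fold lower number from compound 1 to compound 3 (0.51 log units; beyond the scatter), while lengthening the chain by a methyl group gave a 1.1-fold higher number from compound 2 to compound 3 (0.02 log units; within the scatter). No branched or shorter chain has been measured, so whether the shorter branched chain keeps the full gain of the longer chains cannot be read from these data. A small step upward from compound 3 is expected, because compound 1 without any chain gives 64 nM. Compound 4 is therefore estimated at 32 nM in this assay, with a range of 13 nM to 80 nM, meaning an expected step of a 1.6-fold higher number from compound 3 to compound 4 (0.20 log units; within the scatter).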

Compound 4, inhibition constant: 198 nM
Compound 4: the middle estimate sits 6.2-fold (0.79 log units) below what was measured; measured number above the stated range.
By their numbers in this assay, from the lowest: compounds 2 and 3 (each within the scatter of the next); then compound 1; then compound 4.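

At this amide nitrogen, adding a chain does not by itself lower the number. In this assay, sec-butyl in place of the amide hydrogen gives a 3.1-fold higher number from compound 1 to compound 4 (0.49 log units; beyond the scatter) and so moves the number the opposite way from hexyl and heptyl, which both lowered it. Set against the longer chains, the change gives a 9.9-fold higher number from compound 3 to compound 4 (1.00 log units; beyond the scatter) and a 10-fold higher number from compound 2 to compound 4 (1.02 log units; beyond the scatter) and shows that the choice of group here can matter far more than the step from hexyl to heptyl suggested. No measurement at hand explains this behaviour of sec-butyl.

The compounds shown cannot tell whether the higher number goes with the branch in sec-butyl or with its shorter chain, and a straight butyl chain on the same nitrogen would help to separate those two changes. Going by these compounds, it also remains open how a branched heptyl chain, a cyclopentyl ring or a chain longer than heptyl would read at this position.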